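The source may report more compounds than this note shows. Statements on the series, on what has been measured and on what is new or still open speak of the compounds shown alone.

In a functional assay on PC-3 cells (Homo sapiens) for inhibition, read by CellTiter-Glo, with a stated time of 72 h (on this read-out lower numbers stand for higher toxicity in this test and higher numbers for lower toxicity in this test), compound 1 `CC1=C(CC(=O)N2CCN(CCCN(C)C)CC2)c2cc(F)ccc2/C1=C\c1ccc([S+](C)[O-])cc1` is reported only as a limit of the assay, > 50000 nM. Compound 2 `CC1=C(CC(=O)N2CCN(c3ccncc3)CC2)c2cc(F)ccc2/C1=C\c1ccc([S+](C)[O-])cc1` gives 21900 nM, and compound 3 `CC1=C(CC(=O)N(C)CCN(C)S(C)(=O)=O)c2cc(F)ccc2/C1=C\c1ccc([S+](C)[O-])cc1` gives 42600 nM, within the scatter of compound 2. Compound 4 `CC1=C(CC(=O)N(C)CCN(C)S(=O)(=O)c2ccc(C)cc2)c2cc(F)ccc2/C1=C\c1ccc([S+](C)[O-])cc1` differs from compound 3 by 4-methylphenyl in place of methyl on a sulfonyl sulfur. Among the measured compounds shown here, no measured step touches that sulfonyl group. The closest guides exchange whole groups, namely a 1.9-fold higher number from compound 2 to compound 3 (0.29 log units; within the scatter) and an at least 1.1-fold lower number from compound 1 to compound 3 (0.06 log units; that floor lies within the scatter). For the measured compounds named here, the one step clearly beyond the scatter, an at least 2.2-fold lower number from compound 1 to compound 2 (0.35 log units; beyond the scatter), brought in pyridin-4-yl, also a ring, so a modest move towards lower numbers is expected in this assay. The estimated step is a 2.1-fold lower number from compound 3 to compound 4 (0.33 log units; beyond the scatter). Compound 4 is expected at 20000 nM, within an estimated range of 7000 nM to 50000 nM.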

Compound 4, half-maximal cytotoxic concentration: 11000 nM
Compound 4: middle estimate off by 1.8-fold (0.26 log units), on the high side, and the stated range covers the measured number.
By their numbers in this assay, from the lowest: compounds 4, 2 and 3 (each within the scatter of the next, the first and the last beyond it). At a limit, above all of these: compound 1.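

Among the compounds shown here, compound 4 gives the first reading at the sulfonyl sulfur: in this assay, 4-methylphenyl in place of methyl gives a 3.9-fold lower number from compound 3 to compound 4 (0.59 log units; beyond the scatter), a step beyond the scatter. The number therefore responds to this group alone, with the rest of the amide side chain unchanged. The data shown give no reason for this step.

The step brings in the ring and its methyl together, so a plain phenyl would be needed to separate them. As far as these compounds go, whether an amine or a carboxylic acid on that ring would move the number further remains open.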